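This account rests on a few compounds, and the source may have more. Where it says the series, first, only, none or still open, it means among the compounds named here.

Compound 1 `COc1ccccc1C[C@H]1C(=O)OC[C@@H]1Cc1ccccc1` in a functional assay on HL-60 cells (Homo sapiens) for cytotoxicity, read by WST assay, with a stated time of 48 h; on this read-out higher numbers stand for an effect only at larger amounts of compound and lower numbers for an effect already at smaller amounts: 79000 nM
Compound 2 `O=C1OC[C@H](Cc2ccccc2)[C@H]1Cc1ccccc1OC(F)(F)F` in this assay: 39000 nM
Compound 3 `Cc1ccccc1C[C@H]1C(=O)OC[C@@H]1Cc1ccccc1` in this assay: 57000 nM

Compound 3 has the second highest number of the three, but that rank carries little weight. The measurements show a 1.4-fold lower number from compound 1 to compound 3 (0.14 log units; within the scatter) and a 1.5-fold higher number from compound 2 to compound 3 (0.16 log units; within the scatter), so it cannot be told apart from either of the other two.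

The next compound is compound 4 `O=C1OC[C@H](Cc2ccccc2)[C@H]1Cc1ccccc1F`, and the structural change is fluoro in place of methyl on an aromatic carbon. In words, this is fluoro in place of methyl on an aromatic carbon, ortho to a large group. Among the compounds with values here, no measured pair makes this exact swap, and no measured compound carries fluoro, so the evidence is indirect.

The three measured steps all exchange the group at that carbon. Two of them, the ones involving compound 3, stay within the scatter. Within the data shown here, the only step beyond it is a 2.0-fold lower number from compound 1 to compound 2 (0.31 log units; beyond the scatter), and that one is modest. With so few compounds the basis is thin, but no step beyond the scatter is expected in this assay, and so no direction is predicted.

The expected step is a 1.0-fold lower number from compound 3 to compound 4 (0.02 log units; within the scatter). For compound 4 the estimated value is 55000 nM, with an expected range from 28000 nM to 110000 nM.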

Compound 4, half-maximal effective concentration: 72000 nM
Beside the measured number, compound 4's estimate is 1.3-fold (0.12 log units) below it; the range from low to high includes it.
By their numbers in this assay, from the lowest: compounds 2, 3, 4 and 1 (each within the scatter of the next, the first and the last beyond it).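

Fluoro now joins methyl, methoxy and trifluoromethoxy at this aromatic carbon, ortho to a large group, and in this assay it cannot be told apart from any of the three (a 1.3-fold higher number from compound 3 to compound 4 (0.10 log units; within the scatter); a 1.8-fold higher number from compound 2 to compound 4 (0.27 log units; within the scatter); a 1.1-fold lower number from compound 1 to compound 4 (0.04 log units; within the scatter)). Within the data shown here, until now the only step beyond the scatter at this carbon was the one between the methoxy and trifluoromethoxy groups (a 2.0-fold lower number from compound 1 to compound 2 (0.31 log units; beyond the scatter)), and compound 4 lies within the scatter of both of those compounds, so it sides with neither and adds no second step of that kind. Nothing measured beyond these cell numbers bears on this result.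

The compounds shown leave open whether any group at this carbon can give a clear step in this assay, since all four carry a small neutral group with no ring, and an amine, a carboxylic acid or a longer chain such as butyl would test that. Also open, as far as these compounds go, is what plain hydrogen at this carbon would give, and whether fluoro on a different carbon of the same ring would read the same.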